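The source may report more compounds than this note shows. Statements on the series, on what has been measured and on what is new or still open speak of the compounds shown alone.

Compound 1 `Cc1nc(N)c2nc(-c3ccccc3)sc2n1` gives 34 nM in an assay on CHO cells for displacement of a labelled ligand from adenosine receptor A1 (Homo sapiens), read by scintillation counting, with a stated time of 3 h (on this read-out lower numbers stand for stronger inhibition and higher numbers for weaker inhibition), the lowest of the three numbers in hand. Compound 2 `Nc1nc(-c2ccccc2)nc2sc(-c3ccccc3)nc12` gives 148 nM in this assay, and compound 3 `N#Cc1cccc(-c2nc(N)c3nc(-c4ccccc4)sc3n2)c1` gives 594 nM. The measured steps are a 4.4-fold higher number from compound 1 to compound 2 (0.64 log units; beyond the scatter), a 17-fold higher number from compound 1 to compound 3 (1.24 log units; beyond the scatter) and a 4.0-fold higher number from compound 2 to compound 3 (0.60 log units; beyond the scatter); each of them changes a group on an aromatic carbon. Compound 4 `Cc1nc(NC(=O)c2ccccc2)c2nc(-c3ccccc3)sc2n1` differs from compound 1 by benzoyl in place of hydrogen on a nitrogen on an aromatic ring. Going by the values given here, no measured step touches that nitrogen, so none bears directly on this change; the series so far shows only that every enlargement of a substituent on the shared core has raised the number, by modest to large amounts. For compound 4 a modest rise in number is therefore expected, a 2.6-fold higher number from compound 1 to compound 4 (0.42 log units; beyond the scatter). Compound 4 is estimated at 90 nM, within 20 nM to 400 nM.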

Compound 4, inhibition constant: 935 nM
Compound 4: the middle estimate sits 10-fold (1.02 log units) below what was measured; the whole stated range lies below it.
By their numbers in this assay, from the lowest: compound 1; then compound 2; then compounds 3 and 4 (each within the scatter of the next).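

Benzoyl in place of hydrogen on the nitrogen on the aromatic ring gives a 28-fold higher number from compound 1 to compound 4 (1.44 log units; beyond the scatter) in this assay and counts as a large step. This first measured change at that nitrogen shows that the number also responds to substitution there, and not only to changes on aromatic carbon. No evidence on the reason for this rise is at hand. The compounds shown leave open whether the rise follows the carbonyl or the phenyl ring of benzoyl, a question that acetyl or benzyl on that nitrogen would help to separate.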